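Catechol in place of anisole on the benzylamine side chain

The source may report more compounds than this note shows. Statements on the series, on what has been measured and on what is new or still open speak of the compounds shown alone.

Of the compounds shown here, three sharing one core have been tested in a functional assay on BMMC cells (Mus musculus, strain C57BL/6) for inhibition, with stated times of 5 days and 48 h; on this read-out lower numbers stand for stronger inhibition and higher numbers for weaker inhibition. Compound 1 `C=C1CC[C@@H]2[C@](C)(CO)[C@H](O)CC[C@@]2(C)[C@@H]1CCC1C(=O)OC[C@H]1O` carries a free hydroxymethyl group and a saturated lactone; in this assay compound 1 gives only a limit, > 30000 nM, with no number behind it. Compound 2 `C=C1CC[C@@H]2[C@](C)(CNCc3ccccc3)[C@H](O)CC[C@@]2(C)[C@@H]1/C=C/C1=CCOC1=O` bears a benzylamine and an unsaturated lactone and gives 960 nM. Compound 3 `C=C1CC[C@@H]2[C@](C)(CNCc3ccc(OC)cc3)[C@H](O)CC[C@@]2(C)[C@@H]1/C=C/C1=CCOC1=O` differs from compound 2 by a single group, a 1.3-fold lower number from compound 2 to compound 3 (0.11 log units; within the scatter), and gives 750 nM. Compound 3 thus sits at the lower of the two numbers shown, though its distance from compound 2 is within the scatter.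

Compound 4 `C=C1CC[C@@H]2[C@](C)(CNCc3ccc(O)c(O)c3)[C@H](O)CC[C@@]2(C)[C@@H]1/C=C/C1=CCOC1=O` is not yet measured. It differs from compound 3 by 3,4-dihydroxyphenyl in place of 4-methoxyphenyl on a saturated chain carbon bound to an amine nitrogen. Among the measured compounds shown here, the only measured step that touches this part of the molecule is that from compound 2 to compound 3, and it stayed within the scatter, so the aromatic ring on the amine appears to tolerate substitution without a large shift. Nothing measured speaks to two hydroxyls in place of one methoxy. Compound 4 is therefore expected to stay near compound 3, a step of a 1.1-fold higher number from compound 3 to compound 4 (0.03 log units; within the scatter) in this assay, with no direction claimed beyond the scatter. The estimate for compound 4 is 800 nM, between 250 nM and 2500 nM.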

Compound 4, half-maximal inhibitory concentration: 9440 nM
Compound 4: middle estimate off by 12-fold (1.07 log units), on the low side, and the stated range ends below it.
By their numbers in this assay, from the lowest: compounds 3 and 2 (each within the scatter of the next); then compound 4. At a limit, above all of these: compound 1.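

In this assay, the aromatic ring on a saturated chain carbon bound to an amine nitrogen turns out not to accept every substitution, since 3,4-dihydroxyphenyl in place of 4-methoxyphenyl gives a 13-fold higher number from compound 3 to compound 4 (1.10 log units; beyond the scatter). The same holds when the new ring is set against plain phenyl, with a 9.8-fold higher number from compound 2 to compound 4 (0.99 log units; beyond the scatter), whereas methoxy in place of hydrogen on that ring gave only a 1.3-fold lower number from compound 2 to compound 3 (0.11 log units; within the scatter), so the tolerance suggested by that earlier step does not extend to this change. Nothing measured among these compounds gives a reason for the weaker inhibition seen with the 3,4-dihydroxyphenyl ring.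

The compounds shown leave open whether this step belongs to the two hydroxyls together or to either one alone, a question that a ring with a single hydroxyl, or one with two methoxy groups, would address. Also open, going by these compounds, is how other groups on this ring, such as a fluorine or a carboxylic acid, would read in this assay, and whether the change keeps its size on the amide in place of the amine.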